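Oxazoline to thiazoline swap on two pyrazole sulfone cores

The source may hold more compounds than are shown below. What is called first, only, known or untested is meant among the compounds shown, and "the series" means these compounds.

Compound 2 `COc1ccc(C2=NN(c3ccccc3)C(c3ccc(C)cc3)C2S(=O)(=O)CC2=NCCO2)cc1` in a functional assay, tested at 50 ug/mL (on this read-out higher numbers stand for a stronger effect at the one concentration tested and lower numbers for a weaker effect), gives 62.5% and compound 3 `COc1ccc(C2=NN(c3ccccc3)C(c3ccc(C)cc3)C2S(=O)(=O)CC2=NCCS2)cc1` gives 42.6%. The step of a number 19.9 percentage points lower from compound 2 to compound 3 (beyond the scatter) comes from the change (a group of 5 heavy atoms (3 carbon, 1 nitrogen, 1 sulfur; one five-membered non-aromatic ring with 2 hetero atoms) in place of a group of 5 heavy atoms (3 carbon, 1 nitrogen, 1 oxygen; one five-membered non-aromatic ring with 2 hetero atoms), on a saturated chain carbon bound to a sulfonyl sulfur). Compound 1 `O=S(=O)(CC1=NCCO1)c1c(-c2ccc(Cl)cc2)nn(-c2ccccc2)c1-c1ccc(Cl)cc1` in this assay gives "not active" (no number reported), with no number behind it. The difference between the core of compound 1 and the core of compound 2 is not broken down here. Compound 4 `O=S(=O)(CC1=NCCS1)c1c(-c2ccc(Cl)cc2)nn(-c2ccccc2)c1-c1ccc(Cl)cc1` is not yet measured; it arises from compound 1 by a group of 5 heavy atoms (3 carbon, 1 nitrogen, 1 sulfur; one five-membered non-aromatic ring with 2 hetero atoms) in place of a group of 5 heavy atoms (3 carbon, 1 nitrogen, 1 oxygen; one five-membered non-aromatic ring with 2 hetero atoms), on a saturated chain carbon bound to a sulfonyl sulfur, the same change and the same place as from compound 2 to compound 3. That earlier step was a modest loss, so a step of similar size or a flat outcome is expected from compound 1 to compound 4, resting only on compound 1 giving "not active" (no number reported) and on the step of a number 19.9 percentage points lower from compound 2 to compound 3 (beyond the scatter). For compound 4 the estimate in this assay is 10%, expected between 0% and 30%, most likely again reported without a number.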

Compound 4, a percentage reported as activity, at one concentration (the size of the read-out at that concentration, not a potency): "not active" (no number reported)
Compound 4 has no reported number here; there is nothing to compare the estimate with.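

In this assay compound 1 gives "not active" (no number reported) and compound 4 gives "not active" (no number reported) so no step can be read between them. Nothing shown bears on this result. From the compounds shown here alone, whether the ring swap changes activity on the core of compound 1 remains open.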